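The source may report more compounds than this note shows. Statements on the series, on what has been measured and on what is new or still open speak of the compounds shown alone.

Measured so far in an ADME assay on J774 cells (Mus musculus) for cytotoxicity, read by resazurin assay, with a stated time of 24 h; a lower number here means a stronger inhibitor, a higher number a weaker inhibitor:
Compound 1 `Cc1ncc([N+](=O)[O-])n1CCCCBr` gives 61 ug/mL.
Compound 2 `Cc1ncc([N+](=O)[O-])n1CCCN1CCN(c2ccnc3cc(Cl)ccc23)CC1` gives only the limit > 100 ug/mL.
Compound 3 `Cc1ncc([N+](=O)[O-])n1CCCCN1CCN(c2ccnc3cc(Cl)ccc23)CC1` gives only the limit > 100 ug/mL.

Compound 3 therefore stands at the upper end of what this assay reports, as a limit rather than a number. Compound 2 sits at the same limit. For the measured compounds named here, the one step among the measured compounds that touches the chain, a step that the two limits leave unreadable from compound 2 to compound 3, cannot be read in size because the limit of > 100 ug/mL in this assay, at which 2 of the 3 values shown sit, covers both of its ends. Going by the values given here, compound 1, the only compound with a numerical value, carries a bromine-terminated chain instead of the ring amine and gives no guidance on chain length within the amine series.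

Compound 4 `Cc1ncc([N+](=O)[O-])n1CCCCCN1CCN(c2ccnc3cc(Cl)ccc23)CC1` differs from compound 3 by (2-methyl-5-nitro-1H-imidazol-1-yl)methyl in place of 2-methyl-5-nitro-1H-imidazol-1-yl on a saturated chain carbon, four bonds along the chain from an amine nitrogen in a ring. Among the compounds with values here, the only comparable step is unreadable, so there is no basis to expect a move beyond the scatter; the step from compound 3 to compound 4 is expected to be a step that the limit leaves unreadable from compound 3 to compound 4, most likely again ending at the limit. Compound 4 is therefore expected to give about 120 ug/mL, within 60 ug/mL to 250 ug/mL.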

Compound 4, half-maximal inhibitory concentration: 28.9 ug/mL
Compound 4: middle estimate off by 4.2-fold (0.62 log units), on the high side; measured number outside the range, below it.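

In this assay, adding the one carbon at this place, with (2-methyl-5-nitro-1H-imidazol-1-yl)methyl entering for 2-methyl-5-nitro-1H-imidazol-1-yl, gives an at least 3.4-fold lower number from compound 3 to compound 4 (0.53 log units; beyond the scatter). The size of this step is a bound and not an exact figure, yet it shows that chain length at this place can move the read-out beyond the scatter. The earlier step along this chain could not show that, because both of its ends sit at a limit: the limit of > 100 ug/mL in this assay, at which 2 of the 4 values shown sit.

The compounds shown leave open whether a longer chain than that of compound 4 would lower the number further or reverse the change. They also leave open how far compound 2 and compound 3 actually lie from each other, and whether the change from compound 3 to compound 4 marks a gradual trend or a sharp threshold.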